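A few compounds are considered here, and "the series" means these few. Any claim that something is new, unique, unknown or untested is made for them only; others in the source may bear on it.

Compound 2 `CC(C)C[C@@H]1NC(=O)[C@H](CC(C)C)NC(=O)[C@H](CC(C)C)NC(=O)[C@@H](Cc2ccc(O)cc2)NC(=O)[C@H](CC(C)C)NC1=O` is a cyclic peptide built from a shared core. In a functional assay on BXPC-3 cells (Homo sapiens) for inhibition, tested at 5 uM (on this read-out higher numbers stand for more inhibition at the one concentration tested (going by the name of the read-out) and lower numbers for less inhibition), compound 2 gives 33%, the higher of the two numbers recorded here; compound 1 `CC(C)C[C@@H]1NC(=O)[C@H](Cc2ccccc2)NC(=O)[C@H](CC(C)C)NC(=O)[C@@H](C(C)C)NC(=O)[C@H](CCCCN)NC1=O` gives 16%, a gap beyond the usual scatter. Compound 3 `CC(C)C[C@@H]1NC(=O)[C@H](CC(C)C)NC(=O)[C@H](CC(C)C)NC(=O)[C@@H](Cc2c[nH]c3ccccc23)NC(=O)[C@H](CC(C)C)NC1=O` differs from compound 2 in one place: 1H-indol-3-yl in place of 4-hydroxyphenyl on a saturated chain carbon bound to a saturated ring carbon. With no comparable change measured among these compounds, the step from compound 2 to compound 3 is expected to be small, a number 3 percentage points higher from compound 2 to compound 3 (within the scatter), and not clearly beyond the scatter. Compound 3 is therefore estimated at 36%, within a range from 16% to 56%.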

Compound 3, a percentage reported as inhibition, at one concentration (the size of the read-out at that concentration, not a potency): 30%
Beside the measured number, compound 3's estimate is 6 percentage points above it; low and high end bracket the measured number.
By their numbers in this assay, from the lowest: compound 1; then compounds 3 and 2 (each within the scatter of the next).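

In this assay, putting 1H-indol-3-yl in place of 4-hydroxyphenyl on a saturated chain carbon bound to a saturated ring carbon gives a number 3 percentage points lower from compound 2 to compound 3 (within the scatter). This first single-place comparison shows that the two groups cannot be told apart here, even though 1H-indol-3-yl adds a five-membered ring and has no oxygen. The data offer no explanation for this result. As far as these compounds go, whether an amine or a carboxylic acid at this place would give a similar number remains open, as does the effect of a simple methyl group.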